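Acetyl to dimethylamino on the pendant phenyl ring

A few compounds are considered here, and "the series" means these few. Any claim that something is new, unique, unknown or untested is made for them only; others in the source may bear on it.

Measured so far:
compound 1, `COc1cc(C)cc(-c2c(-c3ccnc(-c4ccc(C(C)=O)cc4)c3)cnn2CC#N)c1`, 81%
compound 2, `COc1cc(C)cc(-c2nn(CC#N)cc2-c2ccc(-c3cccc(C(C)=O)c3)nc2)c1`, 83%

Both compounds share one core and carry a cyanomethyl group on it; they differ in the pyridine linkage and in where the acetyl sits on the outer phenyl ring. In a functional assay on HOP-62 cells (Homo sapiens) for cytotoxicity, read by sulforhodamine B assay, with a stated time of 48 h, tested at 0.01 uM (on this read-out lower numbers stand for a stronger effect and higher numbers for a weaker effect at the one concentration tested), compound 1 gives 81%, and compound 2 gives 83%. The two numbers lie within the scatter of each other, so on the numbers shown compound 1 cannot be told apart from compound 2: both are weak at the single concentration tested.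

Compound 3, `COc1cc(C)cc(-c2c(-c3ccnc(-c4ccc(N(C)C)cc4)c3)cnn2CC#N)c1`, has not been measured. It differs from compound 1 in one place: dimethylamino in place of acetyl on an aromatic carbon

Among the measured compounds shown here, no measured pair shows what this change does, so the expectation rests on compound 1 alone. The step from compound 1 to compound 3 is expected to be small or none beyond the scatter, a number 1 percentage points lower from compound 1 to compound 3 (within the scatter), since compound 1 gives 81% and nothing here points to a marked shift. Compound 3 is therefore estimated at 80%, with a range from 60% to 98%.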

Compound 3, a percentage reported as activity, at one concentration (the size of the read-out at that concentration, not a potency): 62%
Beside the measured number, compound 3's estimate is 18 percentage points above it; the range from low to high includes it.
By their numbers in this assay, from the lowest: compound 3; then compounds 1 and 2 (each within the scatter of the next).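

The acetyl group on the outer phenyl ring is not interchangeable with dimethylamino: in this assay, the change gives a number 19 percentage points lower from compound 1 to compound 3 (beyond the scatter), whereas compounds 1 and 2 differ in more than one place and could not isolate the contribution of this group. The two groups match in heavy-atom count, hydrogen-bond donors and acceptors, and net charge, so these counts do not separate them; they differ in the double bond outside the aromatic rings and in carrying oxygen or nitrogen. No supporting measurement accounts for the step, so the compounds shown give a difference in the read-out but no explanation for it.

Still open, on these data alone, is whether another group at this place, such as a primary amine, a methoxy group, a carboxylic acid or a longer dialkylamino chain, would extend the step or reverse it. Also open, as far as these compounds go, is whether dimethylamino would produce a similar step on the core and pyridine linkage of compound 2, and whether the stronger effect seen at the one concentration tested would also appear at other concentrations.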